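Swapping a ring amine for an open one on a bornyl ester

The source may hold more compounds than are shown below. What is called first, only, known or untested is meant among the compounds shown, and "the series" means these compounds.

Measured so far:
- compound 1, `CC1(C)[C@H]2CC[C@]1(C)[C@H](OC(=O)CN1CCCCC1)C2`: 141000 nM
- compound 2, `CCOC(=O)N1CCN(CCC(=O)O[C@@H]2C[C@@H]3CC[C@@]2(C)C3(C)C)CC1`: 110000 nM
- compound 3, `CCOC(=O)N1CCN(CCCC(=O)O[C@@H]2C[C@@H]3CC[C@@]2(C)C3(C)C)CC1`: 60400 nM

All three compounds are esters of the same bicyclic alcohol, each carrying an amine-bearing side chain, and all were tested in an ADME assay on HEK-293T cells (Homo sapiens) for cytotoxicity, read by MTT assay, with a stated time of 48 h; on this read-out higher numbers stand for lower toxicity in this test and lower numbers for higher toxicity in this test. Compound 1 gives the highest of the three numbers. The number for compound 2 lies within the usual scatter of that for compound 1, so the two cannot be told apart here; compound 3 gives a number that lies beyond the scatter below that of compound 1.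

Compound 4, `CCN(CC)CC(=O)O[C@@H]1C[C@@H]2CC[C@@]1(C)C2(C)C`, has not yet been measured. It differs from compound 1 in one place: diethylamino in place of piperidin-1-yl on a saturated chain carbon bound to a carbonyl carbon. The amine is thus opened from a ring into two short chains while the rest of the molecule is kept. Such a small change is expected to leave the read-out roughly where compound 1 stands, so the step of a 1.1-fold lower number from compound 1 to compound 4 (0.04 log units; within the scatter) is expected to stay within the scatter. For compound 4 the estimate is 130000 nM, with a likely range from 60000 nM to 260000 nM.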

Compound 4, half-maximal cytotoxic concentration: 344000 nM
Beside the measured number, compound 4's estimate is 2.6-fold (0.42 log units) below it; measured number outside the range, above it.
By their numbers in this assay, from the lowest: compounds 3, 2 and 1 (each within the scatter of the next, the first and the last beyond it); then compound 4.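

In this assay the swap of piperidin-1-yl for diethylamino on a saturated chain carbon bound to a carbonyl carbon gives a 2.4-fold higher number from compound 1 to compound 4 (0.39 log units; beyond the scatter) and so points to lower toxicity in this test. Among the compounds shown here, this modest step is the only comparison here in which the compounds differ in one place, and it shows that the amine at this position can move the number by itself, with the rest of the molecule unchanged. Nothing shown here gives a measured reason for the step.

A pyrrolidin-1-yl or dimethylamino group in the same place would help show whether losing the ring or the size of the amine matters more. As far as these compounds go, whether the same swap holds on a longer chain also stays open.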